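This account rests on a few compounds, and the source may have more. Where it says the series, first, only, none or still open, it means among the compounds named here.

Measured so far in an assay on isolated protein for inhibition of 5-hydroxytryptamine receptor 4 (Homo sapiens); on this read-out lower numbers stand for stronger inhibition and higher numbers for weaker inhibition:
compound 1 `CCN1CCN(S(=O)(=O)CCCN2CCC(CNC(=O)c3cccc4c3OCCO4)CC2)CC1` gives 0.0501 nM;
compound 2 `O=C(NCC1CCN(CCCS(=O)(=O)N2CCN(Cc3cccnc3)CC2)CC1)c1cccc2c1OCCO2` gives 0.159 nM;
compound 3 `O=C(NCC1CCN(CCCS(=O)(=O)N2CCOCC2)CC1)c1cccc2c1OCCO2` gives 0.398 nM.

Compound 3 stands highest of the three numbers in this assay, with compound 2 nearest and compound 1 furthest. The step to compound 4 `CCCS(=O)(=O)N1CCN(S(=O)(=O)CCCN2CCC(CNC(=O)c3cccc4c3OCCO4)CC2)CC1` is 4-(propylsulfonyl)piperazin-1-yl in place of morpholin-4-yl on a sulfonyl sulfur. For the measured compounds named here, two measured steps concern the same group on the sulfonyl sulfur: a 7.9-fold higher number from compound 1 to compound 3 (0.90 log units; beyond the scatter), and the change within the piperazine substituent, a 3.2-fold higher number from compound 1 to compound 2 (0.50 log units; beyond the scatter). Moving from morpholine back to a substituted piperazine therefore points toward a lower number, though the propylsulfonyl substituent has no measured match, so the size is uncertain. Compound 4 is expected to lie around 0.16 nM in this assay, range 0.05 nM to 0.5 nM, which would mean a 2.5-fold lower number from compound 3 to compound 4 (0.40 log units; beyond the scatter).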

Compound 4, inhibition constant: 0.1 nM
Compound 4: the middle estimate sits 1.6-fold (0.20 log units) above what was measured, within the range that was stated.
By their numbers in this assay, from the lowest: compounds 1, 4 and 2 (each within the scatter of the next, the first and the last beyond it); then compound 3.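

On the sulfonyl sulfur, 4-(propylsulfonyl)piperazin-1-yl in place of morpholin-4-yl gives a 4.0-fold lower number from compound 3 to compound 4 (0.60 log units; beyond the scatter) in this assay, so a piperazine carrying a sulfonyl group also sits clear of the morpholine. On the ring amine nitrogen, propylsulfonyl in place of ethyl gives a 2.0-fold higher number from compound 1 to compound 4 (0.30 log units; within the scatter), and propylsulfonyl in place of (pyridin-3-yl)methyl gives a 1.6-fold lower number from compound 2 to compound 4 (0.20 log units; within the scatter), so these three substituents are not separated by those two steps. Nothing available explains these differences.

Open, from the compounds shown here alone, is how an unsubstituted piperazine amine or a carboxylic acid on that nitrogen would read. Going by these compounds, a longer chain on the sulfonyl group is also open.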